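The source may hold more compounds than are shown below. What is called first, only, known or untested is meant among the compounds shown, and "the series" means these compounds.

Of the compounds shown here, three have been measured in an assay on CHO cells for displacement of a labelled ligand from adenosine receptor A1 (Homo sapiens); a higher number here means a weaker inhibitor, a lower number a stronger inhibitor. Compound 1 `COc1ccc(-c2c(C#N)c(N)nc(SCc3csc(-c4ccc(Br)cc4)n3)c2C#N)cc1` gives 3.8 nM, compound 2 `COc1ccc(-c2c(C#N)c(N)nc(SCc3csc(-c4ccc(Br)cn4)n3)c2C#N)cc1` gives 53 nM, and compound 3 `COc1ccc(-c2c(C#N)c(N)nc(SCc3csc(-c4ccc(Cl)cn4)n3)c2C#N)cc1` gives 24 nM, the second highest of the three numbers. Compound 4 `COc1ccc(-c2c(C#N)c(N)nc(SCc3csc(-c4ccc(I)cc4)n3)c2C#N)cc1` is not yet measured. Its change from compound 3 is 4-iodophenyl in place of 5-chloropyridin-2-yl on an aromatic carbon. Among the compounds with values here, two measured steps bear on it: a 6.3-fold higher number from compound 1 to compound 3 (0.80 log units; beyond the scatter) and a 2.2-fold lower number from compound 2 to compound 3 (0.34 log units; beyond the scatter). Going from compound 3 to compound 4 largely reverses the first of these; iodo in place of bromo on the phenyl ring is not covered by any measured step. The step is therefore expected to be a fall, a 6.0-fold lower number from compound 3 to compound 4 (0.78 log units; beyond the scatter), back toward the level of compound 1. Compound 4 is estimated at 4 nM, with a range of 1.5 nM to 12 nM.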

Compound 4, inhibition constant: 3.9 nM
For compound 4 the middle estimate is 1.0-fold (0.01 log units) above the measured one; the range from low to high includes it.
By their numbers in this assay, from the lowest: compounds 1 and 4 (each within the scatter of the next); then compound 3; then compound 2.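

In this assay, iodo in place of bromo on the phenyl ring gives no change beyond the scatter (a 1.0-fold higher number from compound 1 to compound 4 (0.01 log units; within the scatter)), so the two halogens are interchangeable on this ring in this pair. The 4-iodophenyl compound also stands apart from both pyridine compounds (a 6.2-fold lower number from compound 3 to compound 4 (0.79 log units; beyond the scatter); a 14-fold lower number from compound 2 to compound 4 (1.13 log units; beyond the scatter)), extending the split between the two 4-halophenyl compounds and the two 5-halopyridin-2-yl compounds, with none of the four going against it. No evidence at hand explains this split. Open, going by these compounds, is whether 4-chlorophenyl would sit with compound 1 and compound 4. Also open, on these data alone, is whether an amine or a carboxylic acid in place of the halogen would keep the number this low.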